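Benzofuran acids against the urate transporter: short-chain variant

A few compounds are considered here, and "the series" means these few. Any claim that something is new, unique, unknown or untested is made for them only; others in the source may bear on it.

Among the compounds with values here, three acids have numbers so far. Compound 1 `CCCCc1oc2ccccc2c1C(=O)c1ccc(OCc2ccc(C(=O)O)cc2)cc1` gives 8% in an assay on HEK293 cells for inhibition of solute carrier family 22 member 12 (Homo sapiens), read by scintillation counting, with a stated time of 8 min, tested at 300 nM; on this read-out lower numbers stand for a weaker effect and higher numbers for a stronger effect at the one concentration tested. Compound 2 `CCc1oc2ccccc2c1C(=O)c1ccc(OCc2cccc(C(=O)O)c2)cc1` gives 3% in this assay. Compound 3 `CCc1oc2ccccc2c1C(=O)c1cc(Br)c(OCc2cccc(OCC(=O)O)c2)c(Br)c1` gives 18% in this assay, the largest of the three numbers; the gap to compound 1 lies within the scatter, the gap to compound 2 beyond it. No pair of these compounds differs in one place only, so no single step has been measured; all three numbers sit at the weak end of the read-out.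

Compound 4 `CCc1oc2ccccc2c1C(=O)c1cc(Br)c(OCCCC(=O)O)c(Br)c1` has not yet been measured in this assay. Against compound 3 it differs in one place: 2-carboxyethyl in place of 3-(carboxymethoxy)phenyl on a saturated chain carbon bound to an oxygen on an aromatic ring. The change takes out a whole ring and shortens the acid-bearing arm while keeping one hydrogen-bond donor.

Within the data shown here, with no measured step to lean on, the expectation is a step of no size beyond the scatter, at most a small fall, since the series as a whole stays low. For compound 4 the number in this assay is expected to be 10%, within 0% to 25%. The step expected is a number 8 percentage points lower from compound 3 to compound 4 (within the scatter).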

Compound 4, a percentage reported as inhibition, at one concentration (the size of the read-out at that concentration, not a potency): 23%
For compound 4 the middle estimate is 13 percentage points below the measured one; measured number inside the range.
By their numbers in this assay, from the lowest: compounds 2, 1, 3 and 4 (each within the scatter of the next, the first and the last beyond it).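

In this assay, within the data shown here, the first single step is a number 5 percentage points higher from compound 3 to compound 4 (within the scatter), so at this position, on a saturated chain carbon bound to an oxygen on an aromatic ring, the change from 3-(carboxymethoxy)phenyl to 2-carboxyethyl leaves the read-out within the scatter. The arm drops from 11 heavy atoms to 5 and loses its six-membered aromatic ring, so for this pair neither that ring nor the larger arm is needed to hold the number at this level. Nothing on hand bears on why so large a change in the arm gives a step of this size.

Still open, on these data alone, is whether a longer chain carrying the carboxylic acid, or a tetrazole in place of the carboxylic acid, would move the number at this position beyond the scatter. Also open, as far as these compounds go, is what the bromine atoms contribute on their own, and whether chlorine or hydrogen in their place would change the read-out with the 2-carboxyethyl arm in place.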